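A few compounds are considered here, and "the series" means these few. Any claim that something is new, unique, unknown or untested is made for them only; others in the source may bear on it.

Values in an ADME assay on MT4 cells (Homo sapiens) for cytotoxicity, with a stated time of 5 days; on this read-out lower numbers stand for higher toxicity in this test and higher numbers for lower toxicity in this test:
Compound 1 `CC(C)N(c1cc(C#CC(C)(C)C)sc1C(=O)O)C(=O)[C@H]1CC[C@H](C)CC1`: > 20000 nM
Compound 2 `CC(C)(C)C#Cc1cc(N(C(=O)[C@H]2CC[C@H](C)CC2)[C@H]2CC[C@H](OC3COC3)CC2)c(C(=O)O)s1`: > 20000 nM
Compound 3 `CC(C)(C)C#Cc1cc(N(C(=O)[C@H]2CC[C@H](C)CC2)[C@H]2CC[C@H](OC3CCOCC3)CC2)c(C(=O)O)s1`: > 20000 nM

Each of these entries is a limit of the assay and not a number. Compound 2 therefore has no exact position and shares (the limit of > 20000 nM in this assay, at which 3 of the 3 values shown sit).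

Compound 4 `CC(C)(C)C#Cc1cc(N(C(=O)[C@H]2CC[C@H](C)CC2)[C@H]2C[C@@H](Oc3cccnc3)C2)c(C(=O)O)s1` has not yet been measured. It carries 3-((pyridin-3-yl)oxy)cyclobutyl in place of 4-((oxetan-3-yl)oxy)cyclohexyl on an amide-type nitrogen.

Among the compounds with values here, two measured steps bear on this change. The first, a step that the two limits leave unreadable from compound 1 to compound 2, changes the group at the same amide-type nitrogen. The second, a step that the two limits leave unreadable from compound 2 to compound 3, alters the group on an oxygen within that substituent. Neither has a readable size, so neither offers a number to carry over. All three measured compounds remain at the limit in this assay, and a similar outcome is expected for compound 4. The expected change is a step that the limit leaves unreadable from compound 2 to compound 4, with no readable shift in either direction anticipated. For compound 4 the estimate is 25000 nM, with an expected range from 12000 nM to 50000 nM.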

Compound 4, half-maximal cytotoxic concentration: > 20000 nM
Compound 4: a limit, no number (the forecaster's own chance of this, stated with the estimate: 85%); the middle value lies beyond the limit too.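

Compound 4 also gives a limit and not a number, so the steps from compound 1 and from compound 2 to compound 4 cannot be read: the limit of > 20000 nM in this assay, at which 4 of the 4 values shown sit. The compounds shown leave open at what concentration any of them turns cytotoxic in this assay, and whether the groups on the amide-type nitrogen differ there at all.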